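Cyano in place of methoxy on a benzyl-substituted core

The compounds below may be only part of what the source reports. "The series", "measured", "known", "first", "only" and "open" are said of these compounds alone.

Compound 1 `Fc1cccc(F)c1-c1nc2ccn(Cc3ccccc3)cc-2n1` gives > 100000 nM in an ADME assay on MDBK cells (Bos taurus) for cytotoxicity (a lower number here means that less compound is tolerated, a higher number that more compound is tolerated), which is a limit of the assay and not a number.
Compound 2 `Cc1cccc(Cn2ccc3nc(-c4ccccc4)nc-3c2)c1` gives > 100000 nM in this assay, again only a limit.
Compound 3 `COc1cccc(Cn2ccc3nc(-c4ccccc4)nc-3c2)c1` gives > 100000 nM in this assay, once more a limit.

Compound 3 thus stands at the top of what the assay can report, and the two other values shown stand there too. Among the measured compounds shown here, the one measured step that is a single change, a step that the two limits leave unreadable from compound 2 to compound 3, cannot be read in size or direction because of the limit of > 100000 nM in this assay, at which 3 of the 3 values shown sit. For the measured compounds named here, nothing among the measured compounds therefore shows how far a change on the benzyl ring moves the read-out.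

The unmeasured compound 4 `N#Cc1cccc(Cn2ccc3nc(-c4ccccc4)nc-3c2)c1` differs from compound 3 by cyano in place of methoxy on an aromatic carbon. Going by the values given here, no measured step bears on this change, and the only neighbouring step is unreadable. With every value shown at the limit, no movement beyond the scatter is expected in this assay, in either direction. Compound 4 is expected to give 100000 nM, estimated between 40000 nM and 300000 nM. The expected step is a number no higher from compound 3 to compound 4 (the limit leaves the size open), most likely reported again as a limit rather than a number.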

Compound 4, half-maximal cytotoxic concentration: > 100000 nM
Compound 4: a limit, no number (the forecaster's own chance of this, stated with the estimate: 80%); the middle value lies on the limit itself.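

Compound 4 also returns only a limit, so its steps from compound 3 and from compound 2 cannot be read in size or direction, because all the values share the same limit: the limit of > 100000 nM in this assay, at which 4 of the 4 values shown sit.

The compounds shown leave open how far methyl, methoxy or cyano on the benzyl ring moves the read-out in this assay at all.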